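A few compounds are considered here, and "the series" means these few. Any claim that something is new, unique, unknown or untested is made for them only; others in the source may bear on it.

In a functional assay on MGC-803 cells (Homo sapiens) for inhibition, read by sulforhodamine B assay (on this read-out higher numbers stand for weaker inhibition and lower numbers for stronger inhibition), the three measured compounds gave: compound 1 `O=C1C(Nc2cccc(Cl)c2)=CC(=O)c2c1nc1n2[C@H]2OC[C@@H](O)[C@H]2OC1` 1530 nM; compound 2 `O=C1C=C(NCc2ccccc2)C(=O)c2c1nc1n2[C@H]2OC[C@@H](O)[C@H]2OC1` 2670 nM; compound 3 `CCCc1ccc(NC2=CC(=O)c3nc4n(c3C2=O)[C@H]2OC[C@@H](O)[C@H]2OC4)cc1` 1560 nM.

Compound 1 has the lowest of these three numbers, yet its gaps to compound 3 and to compound 2 both fall within the usual scatter, so no order can be read among them. Compound 4 `O=C1C(Nc2ccc(C(F)(F)F)cc2)=CC(=O)c2c1nc1n2[C@H]2OC[C@@H](O)[C@H]2OC1` differs from compound 1 in one place: 4-(trifluoromethyl)phenyl in place of 3-chlorophenyl on an amine nitrogen. Among the measured compounds shown here, the only measured step in this set, a 1.7-fold lower number from compound 2 to compound 3 (0.23 log units; within the scatter), exchanged one group on the same amine nitrogen for another and stayed within the scatter; no measured pair compares a 3-chlorophenyl with a 4-(trifluoromethyl)phenyl. The step of a 1.0-fold lower number from compound 1 to compound 4 (0.01 log units; within the scatter) is therefore expected to stay within the scatter. The estimate for compound 4 in this assay is 1500 nM, within 600 nM to 4000 nM.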

Compound 4, half-maximal inhibitory concentration: 1860 nM
The estimate for compound 4 lay 1.2-fold (0.09 log units) below the measured number; low and high end bracket the measured number.
By their numbers in this assay, from the lowest: compounds 1, 3, 4 and 2 (each within the scatter of the next).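

In this assay the exchange gave a 1.2-fold higher number from compound 1 to compound 4 (0.08 log units; within the scatter) and so left the number within the scatter. Among the compounds shown here, this is the first comparison here of two substituted phenyl groups on this amine nitrogen, and a 4-(trifluoromethyl)phenyl cannot be told apart from a 3-chlorophenyl, although it brings more heavy atoms. Nothing measured here offers an explanation for this result.

Going by these compounds, whether a carboxylic acid, an amine or a longer chain in this place would move the number beyond the scatter remains open.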